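Moving the Methyl Around the Aryl Ketone Ring

This account rests on a few compounds, and the source may have more. Where it says the series, first, only, none or still open, it means among the compounds named here.

Of the compounds shown here, three sharing one core have been measured. Compound 1 `COc1ccc(C(=O)C#Cc2cn(COCCO)c(=O)[nH]c2=O)cc1` gives 20000 nM in a functional assay on HT-29 cells (Homo sapiens) for cytotoxicity; a higher number here means a weaker inhibitor, a lower number a stronger inhibitor. Compound 2 `Cc1ccc(C(=O)C#Cc2cn(COCCO)c(=O)[nH]c2=O)cc1` gives 8000 nM in this assay, and compound 3 `Cc1cccc(C(=O)C#Cc2cn(COCCO)c(=O)[nH]c2=O)c1` gives 14000 nM in this assay. Among these three numbers compound 3 stands second highest; its nearest neighbour is compound 1 and its furthest is compound 2. The step of a 2.5-fold lower number from compound 1 to compound 2 (0.40 log units; beyond the scatter) came with methyl in place of methoxy on an aromatic carbon and lies beyond the scatter, whereas a 1.4-fold lower number from compound 1 to compound 3 (0.15 log units; within the scatter) and a 1.8-fold higher number from compound 2 to compound 3 (0.24 log units; within the scatter) both stay within it.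

Compound 4 `Cc1ccccc1C(=O)C#Cc1cn(COCCO)c(=O)[nH]c1=O` is the next compound, differing from compound 3 by 2-methylphenyl in place of 3-methylphenyl on a carbonyl carbon. The step that bears most directly on this change is the one in which the methyl also changed its place on the ring, a 1.8-fold higher number from compound 2 to compound 3 (0.24 log units; within the scatter), which stayed within the scatter; the step of a 1.4-fold lower number from compound 1 to compound 3 (0.15 log units; within the scatter) did as well. Only a 2.5-fold lower number from compound 1 to compound 2 (0.40 log units; beyond the scatter) exceeded the scatter, and that step exchanged the group rather than moving it. Compound 4 is therefore expected to show no step beyond the scatter, no change at the digits printed from compound 3 to compound 4 (within the scatter). Compound 4 is estimated at 14000 nM in this assay, with a range from 6000 nM to 35000 nM.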

Compound 4, half-maximal inhibitory concentration: 25000 nM
Compound 4: middle estimate off by 1.8-fold (0.25 log units), on the low side; low and high end bracket the measured number.
By their numbers in this assay, from the lowest: compounds 2, 3, 1 and 4 (each within the scatter of the next, the first and the last beyond it).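

With the methyl now measured at all three places, moving it alone is enough to leave the scatter in this assay: 2-methylphenyl in place of 4-methylphenyl on the carbonyl carbon gives a 3.1-fold higher number from compound 2 to compound 4 (0.49 log units; beyond the scatter), although the same atoms are present in both compounds. The shift from 3-methylphenyl to 2-methylphenyl, by contrast, gives a 1.8-fold higher number from compound 3 to compound 4 (0.25 log units; within the scatter) and stays within the scatter, as did the earlier step between compound 2 and compound 3, so compound 3 cannot be separated from either neighbour and only the two outer placements differ. Among these compounds, compound 4 also cannot be separated from the methoxy compound, with a 1.3-fold higher number from compound 1 to compound 4 (0.10 log units; within the scatter) within the scatter, which leaves compound 2 as the only compound set apart from both compound 1 and compound 4, and nothing available here accounts for this dependence on the place of the methyl.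

The compounds shown leave open whether the same ranking of places would hold for a chloro or an amino group in place of the methyl. They also leave open where the plain phenyl ketone, with no group on the ring, would fall relative to compound 2 and compound 4.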